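This account rests on a few compounds, and the source may have more. Where it says the series, first, only, none or still open, it means among the compounds named here.

Compound 1 `Cc1nc(COc2ccc(/C=C3\SC(=O)NC3=O)cc2)cs1`: 18.6%
Compound 2 `O=C1NC(=O)/C(=C/c2ccc(OCc3csc(-c4ccccc4)n3)cc2)S1`: 25.2%
Compound 3 `Cc1ccc(-c2nnc(SCCOc3ccc(/C=C4\SC(=O)NC4=O)cc3)[nH]2)cc1`: 25.2%

All three were measured in a functional assay on the whole organism (strain Wistar) with Rattus norvegicus as the target, with a stated time of 15 days, at a dose of 3 mg/kg by the oral route; on this read-out lower numbers stand for a weaker effect and higher numbers for a stronger effect at the one dose given. Compound 3 stands level with compound 2 at the digits shown, the two together giving the highest of the three numbers, and its gap to compound 1 lies within the scatter. Among the measured compounds shown here, the only one-place step among the measured compounds, a number 6.6 percentage points higher from compound 1 to compound 2 (within the scatter), also lay within the scatter. Compound 4 `O=C1NC(=O)/C(=C/c2ccc(OCCSc3nnc(-c4ccc(Br)cc4)[nH]3)cc2)S1` differs from compound 3 in one place: bromo in place of methyl on an aromatic carbon. For the measured compounds named here, no measured step exchanges methyl for bromo; the earlier step, phenyl in place of methyl on an aromatic carbon, is a different change and offers only a loose guide. The step is therefore expected to stay within the scatter, a number 0.2 percentage points lower from compound 3 to compound 4 (within the scatter), with no set direction. Compound 4 is estimated at 25%, between 12% and 40%.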

Compound 4, a percentage reported as activity, at one dose (the size of the read-out at that dose, not a potency): 28.4%
Beside the measured number, compound 4's estimate is 3.4 percentage points below it; measured number inside the range.
By their numbers in this assay, from the lowest: compounds 1, 2, 3 and 4 (each within the scatter of the next).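

With the 4-methylphenyl to 4-bromophenyl exchange, on an aromatic carbon para to a large group, the read-out in this assay shows a number 3.2 percentage points higher from compound 3 to compound 4 (within the scatter). Among the compounds shown here, at this place, then, bromo and methyl cannot be told apart in this assay, a change the earlier compounds did not test. Nothing at hand bears on the reason for this result. From the compounds shown here alone, whether an amine, a carboxylic acid or a longer chain at this place would give a step beyond the scatter stays open. So does whether bromo and methyl would still read alike at another dose.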